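Pyrrolidine amide variation against NOTUM

A few compounds are considered here, and "the series" means these few. Any claim that something is new, unique, unknown or untested is made for them only; others in the source may bear on it.

Compound 1 `Cc1cc(C(=O)O)c[nH]1` gives 100000 nM in an assay on cells for inhibition of Palmitoleoyl-protein carboxylesterase NOTUM variant C330S (Homo sapiens), read by fluorescence, with a stated time of 40 min; on this read-out higher numbers stand for weaker inhibition and lower numbers for stronger inhibition. Compound 2 `Cc1cc(C(=O)O)c(C)n1-c1ccc(Cl)cc1` gives 860 nM. Compound 3 `COCCNC(=O)C1CCN(c2ccc(Cl)c(C(F)(F)F)c2)C1` gives 3500 nM.

Among the three measured compounds, compound 3 holds the second highest number in this assay, sitting closer to compound 2 than to compound 1, whose value stands far above it. Compound 4 `CN1CN(C(=O)C2CCN(c3ccc(Cl)c(C(F)(F)F)c3)C2)CC1=O` keeps the core of compound 3 and differs only at the amide end, with a group of 7 heavy atoms (4 carbon, 2 nitrogen, 1 oxygen; one five-membered non-aromatic ring with 2 hetero atoms) in place of a group of 5 heavy atoms (3 carbon, 1 nitrogen, 1 oxygen; no ring), on a carbonyl carbon. Among the compounds with values here, no directly comparable step between measured compounds exists, so the effect of exchanging the open-chain amide for the cyclic one is uncertain. A modest change is expected, most likely little beyond the scatter and if anything toward a slightly higher number. Compound 4 is therefore estimated at 4000 nM, within 1500 nM to 12000 nM, an expected step of a 1.1-fold higher number from compound 3 to compound 4 (0.06 log units; within the scatter).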

Compound 4, half-maximal inhibitory concentration: 1400 nM
Compound 4: middle estimate off by 2.9-fold (0.46 log units), on the high side; the whole stated range lies above it.
By their numbers in this assay, from the lowest: compounds 2 and 4 (each within the scatter of the next); then compound 3; then compound 1.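

At this position, on a carbonyl carbon attached to a saturated ring carbon, replacing the open (2-methoxyethyl)amino group with the cyclic group gives a 2.5-fold lower number from compound 3 to compound 4 (0.40 log units; beyond the scatter) in this assay. This shows that the amide end of the shared core affects the read-out and that a five-membered ring with no hydrogen-bond donor is accepted there. Nothing measured here explains the step.

The compounds shown do not separate the ring itself from the loss of the amide hydrogen. On these data alone, how a morpholine amide or a dimethylamide would read at this carbonyl carbon remains open.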